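The source may hold more compounds than are shown below. What is called first, only, known or untested is meant among the compounds shown, and "the series" means these compounds.

Measured so far:
compound 1 `CCc1ccc(NC(=O)c2cccc(/C=C3\CC(=O)N(c4ccccc4)C3=O)c2)cc1` — > 100000 nM
compound 2 `COc1ccc(NC(=O)c2cccc(/C=C3\CC(=O)N(c4ccc(C)cc4)C3=O)c2)cc1` — 93000 nM

Both compounds were tested in an ADME assay on SW480 cells (Homo sapiens) for cytotoxicity, read by MTT assay, with a stated time of 72 h; on this read-out higher numbers stand for weaker inhibition and lower numbers for stronger inhibition. Compound 1 gives > 100000 nM, and this is a limit of the assay rather than a number. Compound 2 gives 93000 nM in this assay. Within the data shown here, no step between compound 1 and compound 2 has been worked out; their two values only show that both sit at the weak end of the read-out, with compound 1 resting at the limit of > 100000 nM in this assay, at which 1 of the 2 values shown sits.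

Compound 3 `O=C(c1cccc(/C=C2\CC(=O)N(c3ccccc3)C2=O)c1)N1CCCC1` has not yet been measured. It differs from compound 1 in one place: pyrrolidin-1-yl in place of (4-ethylphenyl)amino on a carbonyl carbon. Among the measured compounds shown here, with no measured step of this kind at hand, the expectation for compound 3 rests on where compound 1 stands. The step from compound 1 to compound 3 is expected to be a number no higher from compound 1 to compound 3 (the limit leaves the size open), that is, no movement beyond the scatter in this assay. Compound 3 is therefore estimated at 100000 nM, within a range from 40000 nM to 250000 nM, with a fair chance that only a limit is reported once more.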

Compound 3, half-maximal inhibitory concentration: > 100000 nM
Compound 3 gave a limit, no number (the forecaster's own chance of this, stated with the estimate: 55%); the middle value lies on the limit itself.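

In this assay compound 3 gives > 100000 nM, which is a limit of the assay and not a number. Among these compounds, compound 1 also gives only a limit, so no step between compound 1 and compound 3 can be read: the limit of > 100000 nM in this assay, at which 2 of the 3 values shown sit. The compounds shown leave open whether exchanging (4-ethylphenyl)amino for pyrrolidin-1-yl on a carbonyl carbon changes the read-out at all.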